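Sulfonyl for carbamoyl on the shared core: working notes

The compounds below may be only part of what the source reports. "The series", "measured", "known", "first", "only" and "open" are said of these compounds alone.

Measured in a functional assay on K562 cells (Homo sapiens) for inhibition, read by trypan blue exclusion, with a stated time of 72 h (on this read-out higher numbers stand for weaker inhibition and lower numbers for stronger inhibition), so far:
compound 1 `Cn1c(=O)c(S(=O)(=O)c2ccc(Cl)cc2Cl)cc2cnc(Nc3ccc4[nH]ccc4c3)nc21` gives 1000 nM
compound 2 `Cn1c(=O)c(C(=O)Nc2ccc(F)cc2)cc2cnc(Nc3ccc4[nH]ccc4c3)nc21` gives 5000 nM
compound 3 `Cn1c(=O)c(S(=O)(=O)c2ccc(Cl)cc2)cc2cnc(Nc3cccc4[nH]ccc34)nc21` gives 5000 nM

Compound 2 at 5000 nM stands level with compound 3 at the digits shown, and the two share the highest number of the three. Compound 1 lies clearly lower. The next change leads to compound 4 `Cn1c(=O)c(S(=O)(=O)c2ccc(Br)cc2)cc2cnc(Nc3ccc4[nH]ccc4c3)nc21` and puts (4-bromophenyl)sulfonyl in place of (4-fluorophenyl)carbamoyl on an aromatic carbon with the rest of the structure unchanged.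

Among the compounds with values here, one measured step bears on this: a 5.0-fold higher number from compound 1 to compound 2 (0.70 log units; beyond the scatter) with the sulfonyl compound on the lower side. Read in reverse, it suggests a lower number for compound 4, though the aryl substitution differs from that of compound 1. Compound 3 at 5000 nM also carries an arylsulfonyl group and goes against any simple sulfonyl trend, although it differs elsewhere too. The expected result is therefore a 3.3-fold lower number from compound 2 to compound 4 (0.52 log units; beyond the scatter) in this assay as a somewhat smaller move in the same direction. For compound 4 the estimate is 1500 nM with an expected range from 500 nM to 5000 nM for the measurement.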

Compound 4, half-maximal inhibitory concentration: 5000 nM
The estimate for compound 4 lay 3.3-fold (0.52 log units) below the measured number; measured number inside the range.
By their numbers in this assay, from the lowest: compound 1; then compounds 2, 3 and 4 (each within the scatter of the next).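

In this assay, at this aromatic carbon, (4-bromophenyl)sulfonyl and (4-fluorophenyl)carbamoyl cannot be told apart, with no change at the digits printed from compound 2 to compound 4 (within the scatter) for the exchange. The lower number of compound 1 therefore does not extend to both arylsulfonyl compounds on this core: a 5.0-fold higher number from compound 1 to compound 4 (0.70 log units; beyond the scatter) follows from 4-bromophenyl in place of 2,4-dichlorophenyl on the sulfonyl sulfur, so the aryl group on the sulfur matters here. No measured evidence accounts for this difference between the two aryl groups.

The compounds shown leave open whether the lower number of compound 1 goes with 2,4-dichlorophenyl as a whole or could also be reached with 2-chlorophenyl on the sulfonyl sulfur. On these data alone, it is also open how this position responds to an aryl group carrying an amine or a carboxylic acid.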